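The source may hold more compounds than are shown below. What is called first, only, known or untested is meant among the compounds shown, and "the series" means these compounds.

Compound 3, `COc1cccc(-c2c(C)n(Cc3c(F)cccc3F)c(=O)n(C[C@@H](N)C(C)C)c2=O)c1F`, gives 973 nM in an assay on HEK293 cells for binding affinity to Gonadotropin-releasing hormone receptor (Homo sapiens), read by radioligand binding (a lower number here means a stronger inhibitor, a higher number a weaker inhibitor), and stands highest of the three numbers measured. Compound 1, `COc1cccc(-c2c(C)n(Cc3c(F)cccc3F)c(=O)n(C[C@@H](N)C3CCCC3)c2=O)c1F`, gives 94 nM, and compound 2, `COc1cccc(-c2c(C)n(Cc3c(F)cccc3F)c(=O)n(C[C@H](NC(C)C)C3CCCC3)c2=O)c1F`, gives 12 nM. Among the measured compounds shown here, the step that bears most directly on the change now in question is the one from compound 1 to compound 3, a 10-fold higher number from compound 1 to compound 3 (1.01 log units; beyond the scatter), where isopropyl replaced cyclopentyl at the same place. The other two steps, a 7.8-fold lower number from compound 1 to compound 2 (0.89 log units; beyond the scatter) and an 81-fold higher number from compound 2 to compound 3 (1.91 log units; beyond the scatter), concern the amine substitution as well and speak less directly to a change of the alkyl group alone.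

Compound 4, `COc1cccc(-c2c(C)n(Cc3c(F)cccc3F)c(=O)n(C[C@@H](N)CC(C)C)c2=O)c1F`, differs from compound 3 in that (isobutyl in place of isopropyl on a saturated chain carbon bound to an amine nitrogen and a saturated chain carbon). Isobutyl is one carbon larger than isopropyl and, unlike cyclopentyl, carries no ring, so the step is expected to recover part, not all, of the gap seen from compound 1 to compound 3. Compound 4 is therefore expected to show a modest lower number, a 2.4-fold lower number from compound 3 to compound 4 (0.39 log units; beyond the scatter), in this assay. The estimate for compound 4 is 400 nM, within a range from 120 nM to 1300 nM.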

Compound 4, inhibition constant: 39 nM
Compound 4: the middle estimate sits 10-fold (1.01 log units) above what was measured; the measured number lies below the stated range.
By their numbers in this assay, from the lowest: compound 2; then compound 4; then compound 1; then compound 3.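

In this assay, the change from isopropyl to isobutyl on a saturated chain carbon bound to an amine nitrogen and a saturated chain carbon has a large effect, a 25-fold lower number from compound 3 to compound 4 (1.40 log units; beyond the scatter). No ring is needed at this place for a low number, as isobutyl outdoes cyclopentyl with the amine left unsubstituted, a 2.4-fold lower number from compound 1 to compound 4 (0.38 log units; beyond the scatter). Compound 2, with cyclopentyl and an isopropyl on the amine nitrogen, still holds the lowest number of the four, a 3.3-fold higher number from compound 2 to compound 4 (0.51 log units; beyond the scatter).

Nothing available here explains the size of these steps. Still open, from the compounds shown here alone, is whether a longer chain such as n-pentyl, or a benzyl group, would lower the number further at this place, and whether an isopropyl on the amine nitrogen of compound 4 would lower it as well.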